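Diaryl urea series: chloro for trifluoromethyl at compound 3

The source may hold more compounds than are shown below. What is called first, only, known or untested is meant among the compounds shown, and "the series" means these compounds.

compound 1 `COc1cc2cc(Oc3ccc(NC(=O)Nc4ccc(C)cc4)cc3)c(C)nc2cc1OC` — 112%
compound 2 `COc1cc2cc(Oc3ccc(NC(=O)Nc4ccc(Cl)c(C(F)(F)F)c4)cc3)c(C)nc2cc1OC` — -12.5%

In a functional assay on UACC-257 cells (Homo sapiens) for inhibition, read by sulforhodamine B assay, with a stated time of 48 h, tested at 10 uM (on this read-out lower numbers stand for a stronger effect and higher numbers for a weaker effect at the one concentration tested), compound 1 gives 112% and compound 2 gives -12.5%. Going by the values given here, compound 2 stands lowest of the two numbers; its nearest neighbour is compound 1, the only measured step being a number 124.5 percentage points lower from compound 1 to compound 2 (beyond the scatter).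

Compound 3 `COc1cc2cc(Oc3ccc(NC(=O)Nc4ccc(Cl)c(Cl)c4)cc3)c(C)nc2cc1OC` is the next member. It differs from compound 2 by chloro in place of trifluoromethyl on an aromatic carbon. Among the compounds with values here, the one measured step bears on this only loosely: it exchanged the whole aryl group on the urea nitrogen, whereas here a single substituent changes while the chloro group stays. Within the data shown here, no step of this narrower kind has been measured, so the expectation for compound 3 in this assay is a step of a number 17.5 percentage points higher from compound 2 to compound 3 (beyond the scatter), with the retained chloro-bearing aryl argued to keep compound 3 close to compound 2. Compound 3 is therefore estimated at 5%, within -20% to 35%.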

Compound 3, a percentage reported as activity, at one concentration (the size of the read-out at that concentration, not a potency): 1.38%
Estimate against measurement, compound 3: 3.6 percentage points above; the range from low to high includes it.
By their numbers in this assay, from the lowest: compound 2; then compound 3; then compound 1.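

In this assay, chloro in place of trifluoromethyl on this aromatic carbon, ortho to a chloro group, gives a number 13.9 percentage points higher from compound 2 to compound 3 (beyond the scatter), so the effect seen with compound 2 does not depend on trifluoromethyl here, although the exchange is not neutral. The 3,4-dichlorophenyl group also gives a number 110.6 percentage points lower from compound 1 to compound 3 (beyond the scatter), so a second aryl group, beyond 4-chloro-3-(trifluoromethyl)phenyl, separates sharply from 4-methylphenyl on the urea nitrogen. No measurement available here explains the size or direction of either step.

The compounds shown leave open whether a smaller or polar group on this aromatic carbon, such as a nitrile, a methoxy group or an amine, would keep the effect. They also leave open how much the retained chloro group contributes, since it is present in both compound 2 and compound 3.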